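Swapping an Aromatic Substituent: Expected Shift in Lipophilicity

The compounds below may be only part of what the source reports. "The series", "measured", "known", "first", "only" and "open" are said of these compounds alone.

Measured compounds:
Compound 1 `C[C@H]1CC[C@@H]2[C@@H](OC(=O)[C@]23CC(c2ccccc2)=NO3)[C@]2(C)C(=O)C=C[C@@]12O` gives 1.41 in a physicochemical assay for lipophilicity; a higher number here means a more lipophilic compound, a lower number a more polar compound.
Compound 2 `C[C@H]1CC[C@@H]2[C@@H](OC(=O)[C@]23CC(c2ccc(N(C)C)cc2)=NO3)[C@]2(C)C(=O)C=C[C@@]12O` gives 1.51 in this assay.
Compound 3 `C[C@H]1CC[C@@H]2[C@@H](OC(=O)[C@]23CC(c2ccc(O)cc2)=NO3)[C@]2(C)C(=O)C=C[C@@]12O` gives 0.932 in this assay.

Among these three numbers compound 2 stands highest, though its nearest neighbour, compound 1, is within the scatter: a number 0.10 log units higher from compound 1 to compound 2 (within the scatter). The hydroxy-bearing compound 3 sits clearly lower, as seen in a number 0.48 log units lower from compound 1 to compound 3 (beyond the scatter) and a number 0.58 log units lower from compound 2 to compound 3 (beyond the scatter).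

Compound 4 `C[C@H]1CC[C@@H]2[C@@H](OC(=O)[C@]23CC(c2ccccc2Cl)=NO3)[C@]2(C)C(=O)C=C[C@@]12O` has not yet been measured. The change from compound 2 is 2-chlorophenyl in place of 4-(dimethylamino)phenyl on a carbon with a double bond to nitrogen.

For the measured compounds named here, none of the measured steps bears directly on this change. The two informative steps, both modest, concern a hydroxy group entering on the aromatic ring; the dimethylamino step lies within the scatter. Going by the values given here, nothing among the measured compounds carries a chlorine at all. The expectation for compound 4 therefore rests mainly on compound 1, which gives 1.41 with an unsubstituted phenyl, and on the general experience that a halogen on an aromatic ring tends to move a partition coefficient upward rather than down.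

For compound 4 the estimate is 2.05, with a range from 1.6 to 2.5. This expected step, a number 0.54 log units higher from compound 2 to compound 4 (beyond the scatter), would be upward and beyond the scatter, but with considerable uncertainty.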

Compound 4, partition coefficient: 2.09
Beside the measured number, compound 4's estimate is 0.04 log units below it, and the stated range covers the measured number.
By their numbers in this assay, from the lowest: compound 3; then compounds 1 and 2 (each within the scatter of the next); then compound 4.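

In this assay, for the compounds shown here, a chlorine entering the aromatic ring gives a number 0.68 log units higher from compound 1 to compound 4 (beyond the scatter) and is the first such replacement here to raise the number beyond the scatter, whereas hydroxy lowered it beyond the scatter and dimethylamino stayed within the scatter. Going by these compounds alone, the choice of aromatic group on this carbon with a double bond to nitrogen now spans a wider range of values: 2-chlorophenyl in place of 4-hydroxyphenyl gives a number 1.16 log units higher from compound 3 to compound 4 (beyond the scatter) and is the only large step in the set, while 2-chlorophenyl in place of 4-(dimethylamino)phenyl gives a number 0.58 log units higher from compound 2 to compound 4 (beyond the scatter) and is modest. No measurement at hand accounts for the size of these steps.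

The compounds shown leave open how much of the rise depends on where the chlorine sits on the ring, and whether fluoro or bromo would give a similar step. They also leave open what a carboxylic acid on the ring would do to the number, or a small methyl group taking the place of the whole aromatic ring on this carbon.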